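The source may hold more compounds than are shown below. What is called first, only, known or untested is meant among the compounds shown, and "the series" means these compounds.

Among the measured compounds shown here, compound 1 `COc1cc2c(Oc3ccc(NC(=O)N/N=C/c4ccc(Cl)cc4Cl)cc3F)ccnc2cc1OCCCN1CCCCC1` is the one anchor with a number in this set: in a functional assay on MDA-MB-231 cells (Homo sapiens) for cytotoxicity, read by MTT assay, with a stated time of 72 h (on this read-out higher numbers stand for weaker inhibition and lower numbers for stronger inhibition), compound 1 gives 750 nM. Compound 2 `COc1ccc(/C=N/NC(=O)Nc2ccc(Oc3ccnc4cc(OCCCN5CCCCC5)c(OC)cc34)c(F)c2)c(OC)c1` shares the core of compound 1 and carries a 2,4-dimethoxyphenyl on the carbon with a double bond to nitrogen; in this assay compound 2 is recorded as "not determined" (no result reported), so it stands nowhere on the numbers and offers no point of comparison. Compound 3 `COc1cc2c(Oc3ccc(NC(=O)N/N=C/c4ccc(N(C)C)cc4)cc3F)ccnc2cc1OCCCN1CCCCC1` differs from compound 2 by a single exchange, (4-(dimethylamino)phenyl in place of 2,4-dimethoxyphenyl on a carbon with a double bond to nitrogen), that is, 4-(dimethylamino)phenyl in place of 2,4-dimethoxyphenyl on a carbon with a double bond to nitrogen. For the measured compounds named here, with compound 2 unmeasured, the size and direction of this step in this assay cannot be foreseen from the data; the only guide is compound 1. On that basis compound 3 is estimated to give about 1000 nM in this assay, in a range from 300 nM to 4000 nM, and the actual number is awaited.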

Compound 3, half-maximal inhibitory concentration: 1400 nM
Compound 3: middle estimate off by 1.4-fold (0.15 log units), on the low side; low and high end bracket the measured number.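

In this assay the place on a carbon with a double bond to nitrogen now has a second reading, and 4-(dimethylamino)phenyl in place of 2,4-dichlorophenyl gives a 1.9-fold higher number from compound 1 to compound 3 (0.27 log units; within the scatter) and so no separation between the two compounds. At this position, then, a phenyl ring carrying two chlorines and one carrying a dimethylamino group cannot be told apart on this read-out. Nothing available here bears on why the two readings fall so close together.

As far as these compounds go, the exchange from compound 2 to compound 3 cannot be read, since compound 2 has no number, so the standing of 2,4-dimethoxyphenyl stays open. Also open, from the compounds shown here alone, is whether a phenyl carrying a carboxylic acid, or a cyclohexyl ring, at this place would move the number beyond the scatter.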